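Urea for amide on the benzamido arm of compound 1

The source may report more compounds than this note shows. Statements on the series, on what has been measured and on what is new or still open speak of the compounds shown alone.

Working notes on the series. Compound 1 `O=C(Nc1cccc(-c2nc(-c3ccc(NC(=O)c4cccnc4)cc3Cl)no2)c1)c1ccccc1`, tested in a functional assay on MDA-MB-231 cells (Homo sapiens) for antiproliferative activity, read by MTT assay, with a stated time of 72 h (a higher number here means a weaker inhibitor, a lower number a stronger inhibitor), gives 12800 nM, the higher of the two numbers available for the series. Compound 2 `CC(=O)Nc1ccc(S(=O)(=O)Nc2cccc(-c3nc(-c4ccc(NC(=O)c5cccnc5)c(Cl)c4)no3)c2)cc1` gives 4500 nM in this assay, a value that sits beyond the scatter below that of compound 1. Compound 3 `O=C(Nc1ccc(S(=O)(=O)Nc2cccc(-c3nc(-c4ccc(NC(=O)c5cccnc5)cc4Cl)no3)c2)cc1)NC1CCCC1` gives in this assay only a limit, > 10000 nM. That reading is the limit of > 10000 nM in this assay, at which 1 of the 3 values shown sits.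

Compound 4 `O=C(Nc1ccccc1)Nc1cccc(-c2nc(-c3ccc(NC(=O)c4cccnc4)cc3Cl)no2)c1` has not been measured. It differs from compound 1 by anilino in place of phenyl on a carbonyl carbon; cut one bond further out, the change reads benzoyl to phenylcarbamoyl, benzamido to (phenylcarbamoyl)amino. Within the data shown here, no measured pair isolates this change, so the step has no precedent here. The expectation is for no step beyond the scatter, with the range left open in both directions. Compound 4 is estimated in this assay at 9000 nM, between 3000 nM and 30000 nM. The expected step is a 1.4-fold lower number from compound 1 to compound 4 (0.15 log units; within the scatter).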

Compound 4, half-maximal inhibitory concentration: > 10000 nM
Compound 4 was reported as a limit (the forecaster's own chance of this, stated with the estimate: 40%); middle value at least 1.1-fold (0.04 log units) away from the limit.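

No step from compound 1 to compound 4 can be read, because compound 4 stands at a limit in this assay: the limit of > 10000 nM in this assay, at which 2 of the 4 values shown sit.

The compounds shown leave open whether anilino in place of phenyl on a carbonyl carbon changes the antiproliferative reading at all, and in which direction.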